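Shortening a Long Chain on Two Different Cores

The source may hold more compounds than are shown below. What is called first, only, known or untested is meant among the compounds shown, and "the series" means these compounds.

Compound 1 `CCCCCCCCCCN1NN=C(NC(=O)Nc2c(C(C)C)cccc2C(C)C)N1` gives 14 nM in an assay on microsomes from intestine for inhibition of acyl-CoA:cholesterol acyltransferase (Oryctolagus cuniculus); on this read-out higher numbers stand for weaker inhibition and lower numbers for stronger inhibition.
Compound 2 `CCCCCCCCCCCN1NN=C(NC(=O)Nc2c(C(C)C)cccc2C(C)C)N1` gives 9 nM in this assay.
Compound 3 `CCCCCCCCCCCCCCc1cc(NC(=O)Nc2c(C(C)C)cccc2C(C)C)on1` gives 28 nM in this assay.

Compound 2 and compound 1 share one core and differ by a single change, (hydrogen in place of methyl on a saturated chain carbon, ten or more bonds along the chain from an amine nitrogen in a ring). The step this change made is a 1.6-fold higher number from compound 2 to compound 1 (0.19 log units; within the scatter). Compound 3 has another core; the difference between the two cores is not broken down here. Compound 4 `CCCCCCCCCCCCCc1cc(NC(=O)Nc2c(C(C)C)cccc2C(C)C)on1` has not been measured. It differs from compound 3 by hydrogen in place of methyl on a saturated chain carbon, ten or more bonds along the chain from an aromatic carbon. The place differs in its surroundings: in the pair of compound 2 and compound 1 the chain runs from an amine nitrogen in a ring, whereas here it runs from an aromatic carbon, so this is the same kind of change rather than the same change. For compound 4 a step of a 1.4-fold higher number from compound 3 to compound 4 (0.15 log units; within the scatter) is expected, resting on the earlier step of a 1.6-fold higher number from compound 2 to compound 1 (0.19 log units; within the scatter) and on compound 3 with 28 nM. Compound 4 is therefore estimated at 40 nM, between 15 nM and 100 nM.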

Compound 4, half-maximal inhibitory concentration: 13 nM
Estimate against measurement, compound 4: 3.1-fold (0.49 log units) above, and the stated range ends above it.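

In this assay the loss of one carbon from the long chain gives a 2.2-fold lower number from compound 3 to compound 4 (0.33 log units; beyond the scatter) and so stronger inhibition on this core, whereas on the other core the same kind of change gives a 1.6-fold higher number from compound 2 to compound 1 (0.19 log units; within the scatter) and stays within the usual scatter. The two results do not agree: the same change on two cores in this assay, a 1.6-fold higher number (0.19 log units; within the scatter) from compound 2 to compound 1 and a 2.2-fold lower number (0.33 log units; beyond the scatter) from compound 3 to compound 4, 3.4-fold (0.53 log units) apart, beyond the scatter of two such steps. Going by these compounds alone, with a single pair on each core, this shows only that a step measured on one core cannot be relied on for the other; it does not show what causes the gap or whether it holds at other chain lengths.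

Still open, going by these compounds, is how a longer chain would behave on either core. So is the effect of an amine or a carboxylic acid at the far end of the chain.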